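The source may report more compounds than this note shows. Statements on the series, on what has been measured and on what is new or still open speak of the compounds shown alone.

Of the compounds shown here, two sharing one core have been measured in an assay on lysate for inhibition of phosphatidylcholine:ceramide cholinephosphotransferase 2 (Homo sapiens), read by HPLC, with stated times of 30 min and 2 h; on this read-out higher numbers stand for weaker inhibition and lower numbers for stronger inhibition. Among the compounds with values here, compound 2 `O=C(Nc1cccnc1)c1ccccc1OCc1ccccc1OCCCCCCl` gives 670 nM in this assay, and its nearest neighbour, compound 1 `O=C(Nc1cccnc1)c1ccccc1OCc1ccccc1Cl`, gives 1100 nM; the only step between them, a 1.6-fold lower number from compound 1 to compound 2 (0.22 log units; within the scatter), does not separate the two beyond the usual scatter. Compound 3 `O=C(Nc1cccnc1)c1ccccc1OCc1ccccc1OCCCCCCCl` differs from compound 2 by chloromethyl in place of chloro on a saturated chain carbon, five bonds along the chain from an oxygen on an aromatic ring, so the chain that carries the chlorine is lengthened by one carbon. Within the data shown here, the single measured step that bears on this region, a 1.6-fold lower number from compound 1 to compound 2 (0.22 log units; within the scatter), replaced chloro on the aromatic carbon with the whole (5-chloropentyl)oxy chain and still stayed within the scatter; a further one-carbon extension of that chain is therefore expected to move this assay by no more than the scatter, with no direction to favour. Compound 3 is thus expected to read about 620 nM, in a range from 300 nM to 1300 nM, an expected step of a 1.1-fold lower number from compound 2 to compound 3 (0.03 log units; within the scatter).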

Compound 3, half-maximal inhibitory concentration: 470 nM
For compound 3 the middle estimate is 1.3-fold (0.12 log units) above the measured one, within the range that was stated.
By their numbers in this assay, from the lowest: compounds 3, 2 and 1 (each within the scatter of the next, the first and the last beyond it).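

In this assay, the one-carbon extension of the chain does not by itself separate compound 3 from compound 2 (a 1.4-fold lower number from compound 2 to compound 3 (0.15 log units; within the scatter)). Within the data shown here, measured against the chloro of compound 1, however, the (6-chlorohexyl)oxy chain gives the first step beyond the scatter in this set (a 2.3-fold lower number from compound 1 to compound 3 (0.37 log units; beyond the scatter)), a modest one that the (5-chloropentyl)oxy chain of compound 2 did not reach. Nothing among the data shown explains this result.

The compounds shown leave open whether a longer chain, such as 7-chloroheptyl, would carry the trend further or whether the numbers level off at this length. They also leave open whether the terminal chlorine matters at all, which a plain hexyl chain or one ending in a hydroxyl or an amine would test.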